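From furan-3-yl to thiophen-2-yl on compound 3

A few compounds are considered here, and "the series" means these few. Any claim that something is new, unique, unknown or untested is made for them only; others in the source may bear on it.

In a functional assay on HepG2 cells (Homo sapiens) for antiproliferative activity, read by XTT assay, with a stated time of 72 h (a lower number here means a stronger inhibitor, a higher number a weaker inhibitor), compound 1 `COc1ncnc2c1c(-c1ccccc1)cn2[C@@H]1O[C@H](CO)[C@@H](O)[C@H]1O` gives > 20000 nM as a limit, not a number. Compound 2 `COc1ncnc2c1c(-c1cc3ccccc3o1)cn2[C@@H]1O[C@H](CO)[C@@H](O)[C@H]1O` gives > 20000 nM as a limit too. Compound 3 `CSc1ncnc2c1c(-c1ccoc1)cn2[C@@H]1O[C@H](CO)[C@@H](O)[C@H]1O` gives > 15000 nM as a limit as well. Compound 3 therefore has no exact value, and neither do the other two compounds.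

Compound 4 `CSc1ncnc2c1c(-c1cccs1)cn2[C@@H]1O[C@H](CO)[C@@H](O)[C@H]1O` keeps the shared core of compound 3 and carries thiophen-2-yl in place of furan-3-yl on an aromatic carbon, a change thiophen-2-yl in place of furan-3-yl on an aromatic carbon between two five-membered aromatic rings with 1 hetero atom each, oxygen leaving and sulfur entering.

Within the data shown here, only one measured step bears on this, a step that the two limits leave unreadable from compound 1 to compound 2 with 1-benzofuran-2-yl in place of phenyl on an aromatic carbon, and the two limits hide its size. No size can be carried over from it, so no step beyond the scatter is expected in this assay in either direction. This expectation rests on compound 3 at its limit of > 15000 nM and on nothing firmer. The expected step is a number no higher from compound 3 to compound 4 (the limit leaves the size open) and it is only an estimate. For compound 4 the estimated value is 15000 nM with an expected range from 5000 nM to 30000 nM and a report as a bare limit is also quite likely.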

Compound 4, half-maximal inhibitory concentration: > 20000 nM
Compound 4: only a limit was reported; the forecaster's own chance of this, stated with the estimate: 70%; middle value at least 1.3-fold (0.12 log units) from the limit.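

Compound 3 and compound 4 are both reported only as limits in this assay, not as numbers, so the step between them cannot be read. The compounds shown leave open what exact value any of them has in this assay, and whether thiophen-2-yl in place of furan-3-yl shifts that value at all.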